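Plasma half-life notes on the salicylate diester series

The compounds below may be only part of what the source reports. "The series", "measured", "known", "first", "only" and "open" are said of these compounds alone.

Measured compounds:
compound 1 `CC(=O)Oc1ccccc1C(=O)O[C@H]1CO[C@H]2[C@@H]1OC[C@H]2OC(=O)c1snnc1C`, 0.0642 h
compound 2 `CC(=O)Oc1ccccc1C(=O)O[C@H]1CO[C@H]2[C@@H]1OC[C@H]2OC(=O)c1ccccc1`, 0.055 h
compound 3 `COc1cccc(C(=O)O[C@@H]2CO[C@H]3[C@@H]2OC[C@@H]3OC(=O)c2ccccc2OC(C)=O)c1`, 0.0525 h

In an ADME assay on a cell-free system (plasma, Homo sapiens) for metabolic stability, with Plasma (Rattus norvegicus) as the target, read by HPLC, at pH 7.4 (a higher number here means that the compound lasts longer, a lower number that the compound disappears faster), compound 2 stands second highest of the three, with compound 3 nearest and compound 1 furthest, all three numbers sitting within the scatter of one another. Compound 4 `CC(=O)Oc1ccccc1C(=O)O[C@H]1CO[C@H]2[C@@H]1OC[C@H]2OC(=O)c1ccccc1OC(=O)c1ccccc1` is not yet measured. It differs from compound 2 by benzoyloxy in place of hydrogen on an aromatic carbon. Within the data shown here, no measured step adds a group at this position; the nearest comparisons are a 1.0-fold lower number from compound 2 to compound 3 (0.02 log units; within the scatter) and a 1.2-fold lower number from compound 1 to compound 2 (0.07 log units; within the scatter), both small changes on the same carbonyl-borne ring and neither beyond the scatter. On that basis the step of a 1.1-fold lower number from compound 2 to compound 4 (0.04 log units; within the scatter) is expected to stay within the scatter. For compound 4 the expected value is 0.05 h, with a range of 0.025 h to 0.1 h.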

Compound 4, half-life: 0.385 h
Estimate against measurement, compound 4: 7.7-fold (0.89 log units) below; the measured number lies above the stated range.
By their numbers in this assay, from the lowest: compounds 3, 2 and 1 (each within the scatter of the next); then compound 4.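

Benzoyloxy on an aromatic carbon, ortho to a large group, gives a 7.0-fold higher number from compound 2 to compound 4 (0.85 log units; beyond the scatter) in this assay, so the half-life responds to substitution on this ring. The earlier methoxy change, a 1.0-fold lower number from compound 2 to compound 3 (0.02 log units; within the scatter), gave no such sign, and compound 4 is the only compound shown with a step beyond the scatter. Nothing at hand accounts for the rise. Open, on these data alone, is whether the rise belongs to benzoyloxy itself or would also appear with acetoxy, hydroxyl or an amine on the same carbon.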